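Carbonyl substituent swap from compound 2 to compound 3

The source may report more compounds than this note shows. Statements on the series, on what has been measured and on what is new or still open speak of the compounds shown alone.

In an ADME assay on HepG2 cells (Homo sapiens) for cytotoxicity, read by neutral red uptake, with a stated time of 24 h (a higher number here means a weaker inhibitor, a lower number a stronger inhibitor), compound 1 `CC(=O)Oc1c(C(C)C)cc2c3c1OC(=O)[C@@]31CCCC(C)(C)[C@@H]1CC2` gives 294000 nM and compound 2 `CC(C)c1cc2c3c(c1OC(=O)CCl)OC(=O)[C@@]31CCCC(C)(C)[C@@H]1CC2` gives 203000 nM. Within the data shown here, these two values lie within the scatter of each other, so compound 2 cannot be separated from compound 1 on the numbers so far.

The next compound for measurement is compound 3 `CC(C)C(=O)Oc1c(C(C)C)cc2c3c1OC(=O)[C@@]31CCCC(C)(C)[C@@H]1CC2`, which keeps the shared core. The change is isopropyl in place of chloromethyl on a carbonyl carbon, with isopropyl in place of chloromethyl on a carbonyl carbon. Among the measured compounds shown here, one measured step bears on it: a 1.4-fold lower number from compound 1 to compound 2 (0.16 log units; within the scatter), with chloro in place of hydrogen on a saturated chain carbon bound to a carbonyl carbon. For the measured compounds named here, no measured compound yet carries the isopropyl group, so the support for any forecast is thin.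

Resting on compound 1 at 294000 nM and compound 2 at 203000 nM, no step beyond the scatter is expected in this assay, and no direction is favoured. The expected change is a 1.2-fold higher number from compound 2 to compound 3 (0.09 log units; within the scatter). For compound 3 the estimated value is 250000 nM, with an expected range from 120000 nM to 500000 nM.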

Compound 3, half-maximal inhibitory concentration: 112000 nM
Beside the measured number, compound 3's estimate is 2.2-fold (0.35 log units) above it, and the stated range ends above it.
By their numbers in this assay, from the lowest: compounds 3, 2 and 1 (each within the scatter of the next, the first and the last beyond it).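

In this assay, among these compounds, the group on the carbonyl carbon now separates two compounds for the first time: isopropyl in place of methyl gives a 2.6-fold lower number from compound 1 to compound 3 (0.42 log units; beyond the scatter) and this modest step is the only one so far that clears the scatter. Isopropyl in place of chloromethyl gives a 1.8-fold lower number from compound 2 to compound 3 (0.26 log units; within the scatter) and so does not separate these two groups at this position, which means compound 3 cannot be called the strongest of the three, and the methyl to isopropyl step cannot be read as a trend across all three groups. No measurement on hand bears on what lies behind the step from methyl to isopropyl.

The compounds shown leave open whether a longer chain or a tert-butyl group on the same carbonyl carbon would extend this step or leave the number within the scatter of compound 3. They also leave open what an amine or a carboxylic acid in that place would give, since all three groups seen here are small saturated carbon groups, one of them bearing chlorine.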